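Acyl swap on the shared core: compound 2 to compound 3

The compounds below may be only part of what the source reports. "The series", "measured", "known", "first", "only" and "open" are said of these compounds alone.

Within the data shown here, compound 2 `CCCCCCCCNC(=O)[C@@H](NC(=O)c1cc2ccccc2o1)[C@@H](C)O` stands lowest of the two numbers so far: in a functional assay on HepG2 cells (Homo sapiens) for cytotoxicity, read by MTT assay, with a stated time of 48 h (on this read-out higher numbers stand for weaker inhibition and lower numbers for stronger inhibition), compound 2 gives 81300 nM, while compound 1 `CCCCCCCCNC(=O)[C@@H](NC(=O)c1ccco1)[C@@H](C)O` gives 192000 nM. Among the measured compounds shown here, the single measured step, a 2.4-fold lower number from compound 1 to compound 2 (0.37 log units; beyond the scatter), concerns the acyl group on the same carbonyl carbon and is modest. Compound 3 `C/C=C/C=C/C(=O)N[C@H](C(=O)NCCCCCCCC)[C@@H](C)O` differs from compound 2 by penta-1,3-dien-1-yl in place of 1-benzofuran-2-yl on a carbonyl carbon. For the measured compounds named here, no measured step bears directly on this change; the step from compound 1 to compound 2 shows only that exchanging one aromatic acyl group for another moved the number a little. With both aromatic rings gone and an open-chain group in their place, a step of similar or somewhat larger size is expected, more likely towards a higher number, since compound 2 holds the larger ring system that coincided with 81300 nM. For compound 3 the estimated value in this assay is 120000 nM, with a range of 45000 nM to 320000 nM, which is expected to mean a 1.5-fold higher number from compound 2 to compound 3 (0.17 log units; within the scatter).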

Compound 3, half-maximal inhibitory concentration: 102000 nM
Estimate against measurement, compound 3: 1.2-fold (0.07 log units) above; the measured number falls inside the stated range.
By their numbers in this assay, from the lowest: compounds 2, 3 and 1 (each within the scatter of the next, the first and the last beyond it).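

In this assay, penta-1,3-dien-1-yl on a carbonyl carbon whose other neighbour is an amide-type nitrogen carries no ring, yet neither step to compound 3 leaves the scatter (a 1.3-fold higher number from compound 2 to compound 3 (0.10 log units; within the scatter)) (a 1.9-fold lower number from compound 1 to compound 3 (0.27 log units; within the scatter)). Among these compounds, an aromatic ring on this carbonyl carbon is therefore not needed for a number in this range, and compound 3 cannot be ordered against either aromatic acyl compound, leaving (a 2.4-fold lower number from compound 1 to compound 2 (0.37 log units; beyond the scatter)) as the only step here beyond the scatter. No measurement shown gives a reason for this result.

Still open, as far as these compounds go, is whether an acyl group carrying an amine or a carboxylic acid, or a longer saturated chain on the same carbonyl carbon, would move the number beyond the scatter. With the shared core unchanged throughout, its own contribution to the number also remains unresolved.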